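Aryl swap on the ring amine nitrogen

The source may hold more compounds than are shown below. What is called first, only, known or untested is meant among the compounds shown, and "the series" means these compounds.

Compound 3 `O=C(CN1CCN(c2ccc(F)cn2)CC1)Nc1nc2c(s1)CCCC2` gives 600 nM in an assay on isolated protein for inhibition of long-chain fatty acid transport protein 1 (Mus musculus), read by scintillation counting, with a stated time of 20 min (on this read-out higher numbers stand for weaker inhibition and lower numbers for stronger inhibition), the lowest of the two numbers in this set, with compound 1 `O=C(CN1CCN(c2ccc(F)cc2)CC1)Nc1nc2c(s1)CCCC2` at 4000 nM as the nearest. Compound 2 `O=C(CN1CCN(c2ccncc2)CC1)Nc1nc2c(s1)CCCC2` reaches only the assay limit of > 10000 nM (the limit of > 10000 nM in this assay, at which 1 of the 3 values shown sits). Compound 4 `O=C(CN1CCN(c2cccnc2)CC1)Nc1nc2c(s1)CCCC2` differs from compound 3 by pyridin-3-yl in place of 5-fluoropyridin-2-yl on an amine nitrogen in a ring. Going by the values given here, two measured steps bear on this change: a 6.7-fold lower number from compound 1 to compound 3 (0.82 log units; beyond the scatter) and an at least 16-fold lower number from compound 2 to compound 3 (1.22 log units; beyond the scatter), both placing 5-fluoropyridin-2-yl at the lowest number, while an at least 2.5-fold higher number from compound 1 to compound 2 (0.39 log units; beyond the scatter). Replacing that group with pyridin-3-yl is therefore expected to raise the number, by a step of a 5.0-fold higher number from compound 3 to compound 4 (0.70 log units; beyond the scatter), and a limit reading cannot be ruled out. For compound 4 the estimate is 3000 nM, with a range from 1000 nM to 10000 nM.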

Compound 4, half-maximal inhibitory concentration: > 10000 nM
Compound 4: a limit, no number; the forecaster's own chance of this, stated with the estimate: 20%; middle value at least 3.3-fold (0.52 log units) away from the limit.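

In this assay, a pyridine ring on the amine nitrogen in a ring is not enough by itself: pyridin-3-yl in place of 5-fluoropyridin-2-yl gives an at least 16-fold higher number from compound 3 to compound 4 (1.22 log units; beyond the scatter), and pyridin-3-yl in place of 4-fluorophenyl gives an at least 2.5-fold higher number from compound 1 to compound 4 (0.39 log units; beyond the scatter). Among the pyridines shown, only 5-fluoropyridin-2-yl in compound 3 gives a number. The step between compound 2 and compound 4 cannot be read, as both are limits: the limit of > 10000 nM in this assay, at which 2 of the 4 values shown sit.

Open, on these data alone, is whether the fluorine or the pyridin-2-yl attachment carries the gain, which unsubstituted pyridin-2-yl would separate. Also open, as far as these compounds go, is whether 5-chloropyridin-2-yl or 5-methoxypyridin-2-yl would hold it.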